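A few compounds are considered here, and "the series" means these few. Any claim that something is new, unique, unknown or untested is made for them only; others in the source may bear on it.

Compound 1 `Cc1n[nH]c2ccc(-c3nc4cnc(N5CCN(C)CC5)cn4c3Nc3cccc(Cl)c3)cc12`: 0%
Compound 2 `Cc1n[nH]c2ccc(-c3nc4cnc(N5CCN(C)CC5)cn4c3Nc3ccc(Br)cc3Cl)cc12`: 70.5%
Compound 3 `Cc1n[nH]c2ccc(-c3nc4cnc(N5CCN(C)CC5)cn4c3Nc3ccc(F)cc3Br)cc12`: 82.4%

All three share one core and differ only in the ring attached to a nitrogen on an aromatic ring. In a functional assay on MV4-11 cells (Homo sapiens) for inhibition, with a stated time of 120 h, tested at 10 uM (on this read-out lower numbers stand for less inhibition and higher numbers for more inhibition at the one concentration tested (going by the name of the read-out)), compound 3 stands highest of the three numbers; the step of a number 11.9 percentage points higher from compound 2 to compound 3 (beyond the scatter) is modest, while the step of a number 82.4 percentage points higher from compound 1 to compound 3 (beyond the scatter) is large. Compound 4 `Cc1n[nH]c2ccc(-c3nc4cnc(N5CCN(C)CC5)cn4c3Nc3ccc(Cl)cc3Cl)cc12` is not yet measured; its difference from compound 3 is 2,4-dichlorophenyl in place of 2-bromo-4-fluorophenyl on a nitrogen on an aromatic ring. For the measured compounds named here, the steps that bear on it are a number 70.5 percentage points higher from compound 1 to compound 2 (beyond the scatter) and a number 82.4 percentage points higher from compound 1 to compound 3 (beyond the scatter), both large, showing that compound 2 and compound 3, each carrying a two-halogen ring as compound 4 does, sit far above compound 1. Since swapping one two-halogen ring for another gave only the modest step of a number 11.9 percentage points higher from compound 2 to compound 3 (beyond the scatter), the step of a number 7.4 percentage points lower from compound 3 to compound 4 (within the scatter) is expected to stay within the scatter. Compound 4 is therefore estimated at 75%, between 55% and 90%.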

Compound 4, a percentage reported as inhibition, at one concentration (the size of the read-out at that concentration, not a potency): 78.8%
The estimate for compound 4 lay 3.8 percentage points below the measured number; the range from low to high includes it.
By their numbers in this assay, from the lowest: compound 1; then compounds 2, 4 and 3 (each within the scatter of the next, the first and the last beyond it).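

With a number 3.6 percentage points lower from compound 3 to compound 4 (within the scatter) and a number 8.3 percentage points higher from compound 2 to compound 4 (within the scatter), both within the scatter, the 2,4-dichlorophenyl ring cannot be told apart from either of the other two-halogen rings in this assay. Thus chloro in place of bromo on this ring makes no readable difference here, whereas a number 78.8 percentage points higher from compound 1 to compound 4 (beyond the scatter) confirms a third time the large gap to the 3-chlorophenyl ring of compound 1. Nothing available explains these differences. On these data alone, whether a ring needs two halogens remains open, as does how a ring carrying a methoxy group or an amine would compare.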